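Aryl on ring amide nitrogen: compound 3 to compound 4

A few compounds are considered here, and "the series" means these few. Any claim that something is new, unique, unknown or untested is made for them only; others in the source may bear on it.

The series shares one core, seen unsubstituted in compound 3 `O=C1NC(=O)C2(CSC3=C2C(=O)c2ncccc2C3=O)N1`. In a functional assay on ACHN cells (Homo sapiens) for antiproliferative activity, read by MTT assay, with a stated time of 96 h (on this read-out lower numbers stand for stronger inhibition and higher numbers for weaker inhibition), compound 3 gives 80 nM, the second highest of the three numbers measured. Nearest to it stands compound 1 `CN(C)c1ccc(N2C(=O)NC3(CSC4=C3C(=O)c3ncccc3C4=O)C2=O)cc1`, which in this assay gives 90 nM; the two lie within the scatter of each other, as a 1.1-fold lower number from compound 1 to compound 3 (0.05 log units; within the scatter) shows. Furthest stands compound 2 `CCCc1ccc(N2C(=O)NC3(CSC4=C3C(=O)c3ncccc3C4=O)C2=O)cc1`, which in this assay gives 1 nM; the step of an 80-fold higher number from compound 2 to compound 3 (1.90 log units; beyond the scatter) is large and beyond the scatter.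

Compound 4 `O=C1C2=C(C(=O)c3ncccc31)C1(CS2)NC(=O)N(c2ccc(Cl)cc2)C1=O` differs from compound 3 by 4-chlorophenyl in place of hydrogen on an amide-type nitrogen in a ring. Within the data shown here, two measured steps bear on this: the same ring nitrogen carries a 4-(dimethylamino)phenyl in compound 1 and a 4-propylphenyl in compound 2, and the two aryl groups sit far apart in this assay, as a 90-fold lower number from compound 1 to compound 2 (1.95 log units; beyond the scatter) shows. Between the two only the aryl substituent differs, so the outcome for 4-chlorophenyl cannot be fixed from these three compounds alone; a number anywhere between the compound 1 and compound 2 results is consistent with what is measured. On balance a lower number than compound 3 is expected, in the direction of compound 2 but short of it, given that compound 1 with 90 nM shows the step can also be nil.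

For compound 4 the estimate in this assay is 10 nM, with a range from 2 nM to 80 nM; this corresponds to an expected step of an 8.0-fold lower number from compound 3 to compound 4 (0.90 log units; beyond the scatter).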

Compound 4, half-maximal inhibitory concentration: 4 nM
Estimate against measurement, compound 4: 2.5-fold (0.40 log units) above; low and high end bracket the measured number.
By their numbers in this assay, from the lowest: compound 2; then compound 4; then compounds 3 and 1 (each within the scatter of the next).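

In this assay, the gain from an aryl group on the amide-type nitrogen is not confined to compound 2: a 20-fold lower number from compound 3 to compound 4 (1.30 log units; beyond the scatter), while compound 1 goes against this trend and stays within the scatter of compound 3. With the aryl group kept, the substituent on its aromatic carbon sets the outcome, as chloro in place of dimethylamino gives a 23-fold lower number from compound 1 to compound 4 (1.35 log units; beyond the scatter) and chloro in place of propyl gives a 4.0-fold higher number from compound 2 to compound 4 (0.60 log units; beyond the scatter), placing 4-chlorophenyl clearly between the other two aryl groups. The compounds at hand offer no measurement that explains this order.

Going by these compounds, three aryl substituents are too few to show what governs the order, so it remains open where an unsubstituted phenyl, a methoxy group, a longer chain such as butyl, or a carboxylic acid on the aromatic ring would fall. On these data alone, it is also open whether the order of propyl, chloro and dimethylamino holds in any read-out other than this assay.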